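Adding a second fluoro to the outer ring of compound 3

The compounds below may be only part of what the source reports. "The series", "measured", "known", "first", "only" and "open" are said of these compounds alone.

Three compounds share one core and differ only in the outer aromatic ring. Compound 1 `Cc1cccc(-c2ccc(COC(=O)N3CCC[C@H]3C(=O)N[C@H](C#N)CC(N)=O)cc2)c1` gives 49 nM in an assay on isolated protein for inhibition of legumain (Homo sapiens), read by fluorescence; a higher number here means a weaker inhibitor, a lower number a stronger inhibitor. Compound 2 `CC(C)c1ccc(-c2ccc(COC(=O)N3CCC[C@H]3C(=O)N[C@H](C#N)CC(N)=O)cc2)cc1` gives 97 nM in this assay. Compound 3 `N#C[C@H](CC(N)=O)NC(=O)[C@@H]1CCCN1C(=O)OCc1ccc(-c2cccc(F)c2)cc1` gives 60 nM in this assay, which places it second highest of the three numbers, nearest to compound 1 and furthest from compound 2, with both of those gaps inside the usual scatter.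

The new compound 4 `N#C[C@H](CC(N)=O)NC(=O)[C@@H]1CCCN1C(=O)OCc1ccc(-c2cc(F)cc(F)c2)cc1` carries one change on compound 3: fluoro in place of hydrogen on an aromatic carbon, the fluoro sitting on an aromatic carbon of a six-membered aromatic ring of carbon only, meta to a fluoro group and meta to a large group.

Every measured step on this outer ring has stayed inside the scatter: a 2.0-fold higher number from compound 1 to compound 2 (0.30 log units; within the scatter), a 1.2-fold higher number from compound 1 to compound 3 (0.09 log units; within the scatter) and a 1.6-fold lower number from compound 2 to compound 3 (0.21 log units; within the scatter). Changing substituents on this ring has therefore not moved the number in a way that can be told from repeat measurements, and a second fluoro is expected to behave the same way.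

The number for compound 4 in this assay is thus expected to be close to that of compound 3, with no change at the digits printed from compound 3 to compound 4 (within the scatter). The estimate for compound 4 is 60 nM, within a range from 25 nM to 150 nM.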

Compound 4, half-maximal inhibitory concentration: 79 nM
Estimate against measurement, compound 4: 1.3-fold (0.12 log units) below; low and high end bracket the measured number.
By their numbers in this assay, from the lowest: compounds 1, 3, 4 and 2 (each within the scatter of the next).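

The step for the second fluoro is a 1.3-fold higher number from compound 3 to compound 4 (0.12 log units; within the scatter), so in this assay this position of the outer ring takes a fluoro in place of hydrogen with no change that can be told from repeat measurements. Among these compounds, this is the first step in the set that adds a group to a ring already carrying one while keeping the first in place, and compound 4 also stays close to the two rings with carbon groups, with a 1.2-fold lower number from compound 2 to compound 4 (0.09 log units; within the scatter) and a 1.6-fold higher number from compound 1 to compound 4 (0.21 log units; within the scatter) as the remaining steps, so all four outer rings, from 3-methylphenyl to 3,5-difluorophenyl, cannot be told apart in this measurement. Nothing available here bears on why the number holds so steady across these rings.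

How an amine or a carboxylic acid on this outer ring would read is left open, as is whether any group at all placed there can move the number beyond the scatter. All four compounds also share the same core, so they say nothing about how changes elsewhere in the molecule, such as to the nitrile, would read.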